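The compounds below may be only part of what the source reports. "The series", "measured", "known", "first", "only" and "open" are said of these compounds alone.

Measured compounds:
compound 1 `COc1cc(OC)c(OC)cc1/C=C/C(=O)c1cc(Cl)ccc1O`, 2.23 ug/mL
compound 2 `COc1cc(OC)c(-c2cc(=O)c3ccc(O)cc3o2)cc1OC`, 2.15 ug/mL
compound 3 `COc1cc(OC)c(OC)cc1/C=C/C(=O)c1ccc(-c2c[nH]cn2)cc1`, 2.48 ug/mL

All three were tested in a functional assay on cells (Erythrocyte, Rattus norvegicus) for inhibition, read by hemolysis, with a stated time of 1 h; a higher number here means a weaker inhibitor, a lower number a stronger inhibitor. On these numbers compound 1 stands second highest of the three. Its nearest neighbour is compound 2, whose number lies within the scatter of that of compound 1, and its furthest is compound 3, which also lies within the scatter. The three compounds therefore cannot be told apart in this assay.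

Compound 4 `COc1cc(OC)c(OC)cc1/C=C/C(=O)c1cc(O)ccc1O` has not yet been measured. It differs from compound 1 in one place: hydroxy in place of chloro on an aromatic carbon. Read one bond further out, a 5-chloro-2-hydroxyphenyl becomes a 2,5-dihydroxyphenyl. For the measured compounds named here, no pair among the measured compounds differs by this change alone, so no measured step bears on it. Given that compounds 1, 2 and 3 differ from one another in several places yet give numbers within the scatter, the account expects the step in this assay to be small, and none beyond the scatter is likely, with at most a slight rise.

Compound 4 is estimated at 2.8 ug/mL in this assay, within the range 1.4 ug/mL to 5.6 ug/mL. The implied step, a 1.3-fold higher number from compound 1 to compound 4 (0.10 log units; within the scatter), is expected to stay near the scatter.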

Compound 4, half-maximal inhibitory concentration: 2.1 ug/mL
Compound 4: middle estimate off by 1.3-fold (0.12 log units), on the high side, within the range that was stated.
By their numbers in this assay, from the lowest: compounds 4, 2, 1 and 3 (each within the scatter of the next).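

In this assay the change from chloro to hydroxy, on an aromatic carbon meta to a large group and para to a hydroxy group, provides the only single-change comparison among the compounds shown, and the step stays within the scatter (a 1.1-fold lower number from compound 1 to compound 4 (0.03 log units; within the scatter)). The earlier compounds shown here differ from one another in several places and could not speak to this position alone, whereas this pair shows that a 5-chloro-2-hydroxyphenyl can give way to a 2,5-dihydroxyphenyl with no difference that this assay can resolve, even though the entering hydroxy counts one hydrogen-bond donor and one hydrogen-bond acceptor and the leaving chloro neither. No measurement among the data shown offers an explanation for this result.

What the compounds shown leave open is whether any group at this position would move the number beyond the scatter, as only chloro and hydroxy appear here. An amine, a carboxylic acid or a longer chain such as an ethoxy group at the same carbon would test how far this insensitivity extends.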